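The source may hold more compounds than are shown below. What is called first, only, known or untested is meant among the compounds shown, and "the series" means these compounds.

Measured in a functional assay on MGC-803 cells (Homo sapiens) for antiproliferative activity, read by CCK-8 assay, with a stated time of 72 h, tested at 2 uM; on this read-out lower numbers stand for a weaker effect and higher numbers for a stronger effect at the one concentration tested:
compound 1, `Nc1ccccc1NC(=O)c1ccc(CSC(=S)N2CCN(Cc3ccccn3)CC2)cc1`: 23.4%
compound 2, `Nc1ccccc1NC(=O)c1ccc(CSC(=S)N2CCN(c3ccccc3)CC2)cc1`: 42.3%
compound 3, `Nc1ccccc1NC(=O)c1ccc(CSC(=S)N2CCN(c3ncccn3)CC2)cc1`: 28.4%

Compound 3 stands second highest of the three numbers. Its nearest neighbour is compound 1, and the two lie within the scatter of each other, as the step of a number 5 percentage points higher from compound 1 to compound 3 (within the scatter) shows. Compound 2 is the highest of the set, since the step of a number 13.9 percentage points lower from compound 2 to compound 3 (beyond the scatter) is beyond the scatter and so is a number 18.9 percentage points higher from compound 1 to compound 2 (beyond the scatter).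

Compound 4, `Nc1ccccc1NC(=O)c1ccc(CSC(=S)N2CCN(Cc3ccccc3)CC2)cc1`, differs from compound 3 in one place: benzyl in place of pyrimidin-2-yl on an amine nitrogen in a ring. Among the compounds with values here, no measured step matches this change exactly. Within the data shown here, two steps bear on it indirectly. The step of a number 13.9 percentage points lower from compound 2 to compound 3 (beyond the scatter) shows a modest loss when an aromatic ring of carbon only is exchanged for one with two hetero atoms on the ring nitrogen; the reverse is what compound 4 does, though with a benzyl group. The step of a number 18.9 percentage points higher from compound 1 to compound 2 (beyond the scatter) shows that a directly attached phenyl outperforms a methylene-linked heteroaryl, which tempers the expectation. The step expected from this change is therefore a number 5.6 percentage points higher from compound 3 to compound 4 (within the scatter). Compound 4 is estimated to give 34%, with a range from 22% to 47%.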

Compound 4, a percentage reported as inhibition, at one concentration (the size of the read-out at that concentration, not a potency): 18.1%
Beside the measured number, compound 4's estimate is 15.9 percentage points above it; the whole stated range lies above it.
By their numbers in this assay, from the lowest: compounds 4, 1 and 3 (each within the scatter of the next, the first and the last beyond it); then compound 2.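

In this assay, benzyl in place of phenyl on the amine nitrogen in a ring gives a number 24.2 percentage points lower from compound 2 to compound 4 (beyond the scatter) and is the largest step in the set, so a six-membered aromatic ring of carbon only does not by itself secure the high number of compound 2; how that ring is attached to the amine nitrogen matters here. The exchange of pyrimidin-2-yl for a carbon-only aromatic ring also changes direction with that attachment: phenyl gave the higher number, as a number 13.9 percentage points lower from compound 2 to compound 3 (beyond the scatter) shows, whereas benzyl in place of pyrimidin-2-yl gives a number 10.3 percentage points lower from compound 3 to compound 4 (beyond the scatter) and the order is reversed. With the attachment through a saturated chain carbon kept, phenyl in place of pyridin-2-yl gives a number 5.3 percentage points lower from compound 1 to compound 4 (within the scatter) and so leaves the two compounds unseparated, which means that the ring nitrogen of the pyridin-2-yl group makes no readable difference in this pair.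

The compounds shown leave open how a pyridin-2-yl group attached directly to the amine nitrogen, a longer chain ending in phenyl, or a methoxy group on the phenyl ring of compound 2 would read in this assay and whether any of them would go beyond compound 2. No information is available that explains the differences seen among these compounds.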